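Adding a Second Chloro Group to Compound 2

The compounds below may be only part of what the source reports. "The series", "measured", "known", "first", "only" and "open" are said of these compounds alone.

Measured compounds:
Compound 1 `O=c1c(C2N=C(c3ccccc3)SS2)coc2ccccc12`: 18%
Compound 2 `O=c1c(C2N=C(c3ccccc3)SS2)coc2cc(Cl)ccc12`: 57%
Compound 3 `O=c1c(C(=S)Nc2ccccc2)coc2cc(Cl)c(Cl)cc12`: 16%

In a functional assay on COLO 205 cells (Homo sapiens) for inhibition, read by sulforhodamine B assay, with a stated time of 48 h, tested at 100 uM (a higher number here means more inhibition of growth at the concentration tested, a lower number less inhibition of growth), compound 2 stands highest of the three numbers. Compound 1 lies beyond the scatter below it, and compound 3 lies a little further below still, also beyond the scatter.

Compound 4 `O=c1c(C2N=C(c3ccccc3)SS2)coc2cc(Cl)c(Cl)cc12` differs from compound 2 by one change: chloro in place of hydrogen on an aromatic carbon.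

Among the measured compounds shown here, one measured step bears on this change. Going a number 39 percentage points higher from compound 1 to compound 2 (beyond the scatter), the first chloro group on the same ring raised growth inhibition by a large amount. For the measured compounds named here, compound 3 also carries two chloro groups, but its side group differs from that of compound 2 and compound 4, so no step connects it and its low value alone says little about the second chloro group here.

A second chloro group is therefore expected to move the number upward, though not necessarily as far as the first did; the estimated step is a number 8 percentage points higher from compound 2 to compound 4 (within the scatter). Compound 4 is estimated at 65%, within a range from 40% to 88%.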

Compound 4, percent growth inhibition at one concentration: 50%
Estimate against measurement, compound 4: 15 percentage points above, and the stated range covers the measured number.
By their numbers in this assay, from the lowest: compounds 3 and 1 (each within the scatter of the next); then compounds 4 and 2 (each within the scatter of the next).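

In this assay, putting chloro in place of hydrogen at this position, ortho to a chloro group, gives a number 7 percentage points lower from compound 2 to compound 4 (within the scatter), a step that cannot be told from the usual scatter. The same kind of change at the first chloro position gave a number 39 percentage points higher from compound 1 to compound 2 (beyond the scatter), so the large gain from that first chloro group is not repeated by a second one here. Nothing measured in this set gives a reason for the difference between these two steps.

From the compounds shown here alone, whether a different group at this position, such as methoxy, an amine or a carboxylic acid, would move growth inhibition beyond the scatter stays open. Also open, going by these compounds, is what this chloro group would do alone on the core of compound 1, without the first chloro group present.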